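The compounds below may be only part of what the source reports. "The series", "measured", "known", "first", "only" and "open" are said of these compounds alone.

Two compounds in this series have a number in an ADME assay on microsomes from liver (Homo sapiens) for metabolic stability, read by LC-MS, using NADPH, with stated times of 5 min and 30 min, tested at 1 uM; on this read-out lower numbers stand for slow clearance and higher numbers for fast clearance. Compound 1 `CN(C)C(=O)c1cc(-c2cnc(NCc3c(F)ccc4c3CCO4)c3cn[nH]c(=O)c23)n(C)n1` gives 21 mL.min-1.g-1 in this assay. Compound 2 `CN(c1ccccc1)c1cnc(NCc2c(F)ccc3c2CCO3)n2cnnc12` gives 55 mL.min-1.g-1 in this assay; among the two numbers this is the highest, and its nearest neighbour, compound 1, sits lower by a margin beyond the usual scatter. Compound 1 and compound 2 differ in more than one place, so no single substitution has yet been followed from one measured compound to another, and nothing is known of how the series answers to a change at one site.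

Compound 3 `CN(c1cccnc1)c1cnc(NCc2c(F)ccc3c2CCO3)n2cnnc12` differs from compound 2 in one place: pyridin-3-yl in place of phenyl on a nitrogen on an aromatic ring. The rest of the structure, the shared core and the substituted chain on the amine, stays as it is in compound 2. Among the compounds with values here, no measured pair shows this change, so the size of the step is not fixed by the data. A modest step downward in this assay is expected for compound 3, of a size that would not clearly exceed the scatter, a 1.6-fold lower number from compound 2 to compound 3 (0.20 log units; within the scatter). Compound 3 is therefore estimated at 35 mL.min-1.g-1, within a range of 15 mL.min-1.g-1 to 70 mL.min-1.g-1.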

Compound 3, intrinsic clearance in microsomes: 80 mL.min-1.g-1
The estimate for compound 3 lay 2.3-fold (0.36 log units) below the measured number; the measured number lies above the stated range.
By their numbers in this assay, from the lowest: compound 1; then compounds 2 and 3 (each within the scatter of the next).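

In this assay, the series now has its first single-site step, a 1.5-fold higher number from compound 2 to compound 3 (0.16 log units; within the scatter), so pyridin-3-yl in place of phenyl on a nitrogen on an aromatic ring leaves the read-out inside the usual scatter of repeated measurements. Exchanging one ring carbon for a ring nitrogen, which adds one hydrogen-bond acceptor at the same count of 6 heavy atoms, therefore gives no measurable separation between compound 2 and compound 3 at this position. Nothing measured on either group bears on this result, so it stands without an explanation.

Going by these compounds, whether this position responds to a different kind of group, such as a morpholine, a carboxylic acid or a longer alkyl chain, remains open, as does whether pyridin-2-yl or pyridin-4-yl would read the same as pyridin-3-yl. On these data alone, how the read-out follows a change to the methyl on that same nitrogen, for instance to ethyl, or to the substituted chain on the amine, also remains open.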